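This account rests on a few compounds, and the source may have more. Where it says the series, first, only, none or still open, it means among the compounds named here.

Measured so far in an assay on cells for displacement of a labelled ligand from adenosine receptor A1 (Homo sapiens), read by radioligand binding, with a stated time of 60 min, tested at 1 uM; on this read-out higher numbers stand for more inhibition at the one concentration tested (going by the name of the read-out) and lower numbers for less inhibition:
Compound 1 `CC1=C(C(=O)OC(C)C(F)(F)F)C(c2cccs2)NC(=O)N1`: compound 1 gives 12%; 16% (2 entries).
Compound 2 `CCOC(=O)C1=C(C(F)(F)F)NC(=O)NC1c1cccs1`: compound 2 gives 28%.

Compound 2 stands on a single number in this assay; a further entry for it gives no single number. Compound 1 has been measured more than once, and the repeats, (the several entries of compound 1 in this assay, 12%; 16% (2 entries)), stay close to one another. Both compounds sit in the lower part of the scale, so neither displaces much of the labelled ligand at the one concentration tested. Within the data shown here, compound 1 and compound 2 differ in more than one place, so no single step between them can be read.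

Compound 3, `CCOC(=O)C1=C(C(F)(F)F)NC(=O)NC1c1ccoc1`, has not yet been measured. It differs from compound 2 in one place: furan-3-yl in place of thiophen-2-yl on a saturated ring carbon. Among the measured compounds shown here, no pair of measured compounds differs in only one place, so there is no measured step of this kind to lean on. A change of one five-membered aromatic ring for another of the same size is expected to move this assay little; the step of a number 4 percentage points lower from compound 2 to compound 3 (within the scatter) is expected to be small, no larger than the usual scatter, in either direction. Compound 3 is estimated at 24%, with a range from 5% to 42%.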

Compound 3, a percentage reported as inhibition, at one concentration (the size of the read-out at that concentration, not a potency): 37%
Compound 3: middle estimate off by 13 percentage points, on the low side; low and high end bracket the measured number.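

Among these compounds, the first one-place step on this core reads a number 9 percentage points higher from compound 2 to compound 3 (within the scatter) in this assay, with furan-3-yl in place of thiophen-2-yl on the saturated ring carbon. On this evidence, the two rings cannot be ranked against each other at this position, although the exchange swaps sulfur for oxygen and also moves the point of attachment from the 2-position of the ring to the 3-position. The only view of how closely this read-out repeats comes from compound 1, whose entries stay close to one another: the several entries of compound 1 in this assay, 12%; 16% (2 entries)

On these data alone, this single step covers just two five-membered aromatic rings with one hetero atom each, so it remains open how the position responds to something quite different, such as a phenyl ring, a longer alkyl chain or an amine, and the hetero atom and attachment point cannot be judged separately. Among the compounds shown here, compound 1 differs from the other two compounds in more than one place, no step to it can be read, and the places bearing the ethoxycarbonyl and trifluoromethyl groups remain without a one-place comparison.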